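This account rests on a few compounds, and the source may have more. Where it says the series, first, only, none or still open, it means among the compounds named here.

Measured so far:
compound 1 `CC(C)/C(=C1\C(=O)NC(=O)N1C)c1ccc(-c2ccc3cccc(F)c3c2)[nH]c1=O` — 11100 nM
compound 2 `CC(C)C(/C=C1\NC(=O)NC1=O)c1ccc(-c2ccc3cccc(F)c3c2)[nH]c1=O` — 7500 nM
compound 3 `O=C1NC(=O)/C(=C/C2(c3ccc(-c4ccc5cccc(F)c5c4)[nH]c3=O)CCCC2)O1` — 2550 nM

Three compounds sharing one core have been run in a physicochemical assay for solubility, measured as kinetic solubility, at pH 2; a higher number here means a more soluble compound, a lower number a less soluble compound. Compound 1 gives 11100 nM and compound 2 gives 7500 nM; these two numbers lie within the scatter of each other, so nothing separates them. Compound 3 gives 2550 nM, a number beyond the scatter below that of compound 2. Compound 2 thus stands second highest of the three, near compound 1 and clearly apart from compound 3.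

Compound 4 `CC(C)C(/C=C1\SC(=O)NC1=O)c1ccc(-c2ccc3cccc(F)c3c2)[nH]c1=O` has not yet been measured in this assay. It differs from compound 2 in one place: a group of 8 heavy atoms (4 carbon, 1 nitrogen, 2 oxygen, 1 sulfur; one five-membered non-aromatic ring with 2 hetero atoms) in place of a group of 8 heavy atoms (4 carbon, 2 nitrogen, 2 oxygen; one five-membered non-aromatic ring with 2 hetero atoms), on a saturated chain carbon bound to an aromatic carbon and a saturated chain carbon. The entering group carries one hydrogen-bond donor where the leaving group carries two, and one sulfur atom in the ring where the leaving group has a second nitrogen.

For the measured compounds named here, no step between measured compounds covers a change of this kind, so there is no direct anchor. A modest step is expected from compound 2 to compound 4, a 1.4-fold lower number from compound 2 to compound 4 (0.13 log units; within the scatter), downward, likely within the scatter. Compound 4 is therefore estimated at 5500 nM, with a range from 2500 nM to 12000 nM.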

Compound 4, solubility: 4800 nM
Beside the measured number, compound 4's estimate is 1.1-fold (0.06 log units) above it; the range from low to high includes it.
By their numbers in this assay, from the lowest: compounds 3, 4, 2 and 1 (each within the scatter of the next, the first and the last beyond it).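

In this assay, for the compounds shown here, the exchange at the saturated chain carbon bound to an aromatic carbon and a saturated chain carbon gives a 1.6-fold lower number from compound 2 to compound 4 (0.19 log units; within the scatter), the first step at this place that can be read in one change. It shows that putting 1 sulfur into the ring in place of the second nitrogen, with 1 hydrogen-bond donor where there were 2, leaves the number within the scatter of that of compound 2. Nothing among the data shown accounts for this result.

On these data alone, whether an open chain ending in a carboxylic acid or an amine at this same place would move the number beyond the scatter remains open. So does whether the same exchange would give a like step in the setting of compound 3.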